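The source may report more compounds than this note shows. Statements on the series, on what has been measured and on what is new or still open speak of the compounds shown alone.

Measured in an ADME assay on J774 cells (Mus musculus) for cytotoxicity, read by MTT assay, with a stated time of 48 h, tested at 50 ug/mL; a lower number here means a stronger effect, a higher number a weaker effect of the compound at the concentration tested:

Compound 1 `O=C(N/N=C/c1ccccc1)c1cnccn1`: 100%
Compound 2 `O=C(N/N=C/c1ccccc1Cl)c1cnccn1`: 70%
Compound 3 `O=C(N/N=C/c1ccc(Cl)cc1)c1cnccn1`: 83%

Among these three, compound 2 stands lowest; compound 3 is nearest to it, and compound 1 furthest, both gaps lying beyond the scatter. The next compound keeps the core of compound 2 and changes one atom: bromo in place of chloro on an aromatic carbon, giving compound 4 `O=C(N/N=C/c1ccccc1Br)c1cnccn1`. For the measured compounds named here, no measured step swaps one halogen for another. The two known steps, a number 30 percentage points lower from compound 1 to compound 2 (beyond the scatter) and a number 17 percentage points lower from compound 1 to compound 3 (beyond the scatter), each put chloro in place of hydrogen and both lowered the number modestly. A bromo for chloro exchange is a smaller change than that, so the step of a number 5 percentage points lower from compound 2 to compound 4 (within the scatter) is expected to stay within the scatter. Compound 4 is therefore estimated at 65%, with a range from 45% to 85%.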

Compound 4, a percentage reported as activity, at one concentration (the size of the read-out at that concentration, not a potency): 98%
Estimate against measurement, compound 4: 33 percentage points below; the whole stated range lies below it.
By their numbers in this assay, from the lowest: compound 2; then compound 3; then compounds 4 and 1 (each within the scatter of the next).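

In this assay the identity of the halogen matters at this place, ortho to a large group: bromo in place of chloro gives a number 28 percentage points higher from compound 2 to compound 4 (beyond the scatter) and so cancels most of what chloro had done. Bromo in place of hydrogen gives a number 2 percentage points lower from compound 1 to compound 4 (within the scatter), so a halogen here does not lower the number by itself, as compound 2 alone had suggested. Nothing shown explains why chloro and bromo differ here.

On these data alone, whether the lower number belongs to chloro alone stays open, since fluoro, methyl or an amine at this place could fall on either side. Also open, as far as these compounds go, is how bromo behaves where compound 3 carries its chloro.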